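From Hydroxy to Chloro on the Aromatic Ring

A few compounds are considered here, and "the series" means these few. Any claim that something is new, unique, unknown or untested is made for them only; others in the source may bear on it.

This account follows a small series measured in an ADME assay on LLC-PK1 cells (Sus scrofa) for cytotoxicity, read by neutral red uptake; on this read-out lower numbers stand for stronger inhibition and higher numbers for weaker inhibition. There, compound 1 `COC(/C=C/c1ccc(O)cc1)=C1\C(=O)C=C(C)C1=O` gives 3.4 ug/mL. Compound 2 `CC(=O)OC(/C=C/c1ccccc1)=C1\C(=O)C=C(C)C1=O` gives 4.9 ug/mL, a number within the usual scatter of the value for compound 1, so the two cannot be told apart. Compound 3 `CO/C(=C1\C(=O)C=C(C)C1=O)c1ccccc1` returns only a limit, > 10 ug/mL. Compound 1 therefore stands level with compound 2, and it has no true number to be compared with beyond that one.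

The next compound to be tested is compound 4 `COC(/C=C/c1ccc(Cl)cc1)=C1\C(=O)C=C(C)C1=O`. It keeps the core of compound 1 and carries chloro in place of hydroxy on an aromatic carbon, para to a large group (chloro in place of hydroxy on an aromatic carbon). Within the data shown here, no measured pair isolates this change, so any expectation rests on indirect evidence. Compound 2 has no hydroxy group on its aromatic ring, though it differs elsewhere too, and it still gives 4.9 ug/mL. Losing the hydroxy group is therefore not expected to cost much in this assay. The expected change is a 1.2-fold higher number from compound 1 to compound 4 (0.07 log units; within the scatter), a step not expected to go beyond the scatter, with no firm direction. For compound 4 the estimated value is 4 ug/mL, with an expected range from 1.5 ug/mL to 10 ug/mL.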

Compound 4, half-maximal inhibitory concentration: 3.1 ug/mL
Compound 4: middle estimate off by 1.3-fold (0.11 log units), on the high side; the measured number falls inside the stated range.
By their numbers in this assay, from the lowest: compounds 4, 1 and 2 (each within the scatter of the next). At a limit, above all of these: compound 3.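

In this assay, among these compounds, the single change reads as a 1.1-fold lower number from compound 1 to compound 4 (0.04 log units; within the scatter) and is the first step that isolates one place. On an aromatic carbon, para to a large group, chloro can therefore take the place of hydroxy without a difference that can be told from the scatter, even though the hydrogen-bond donor and hydrogen-bond acceptor counted for hydroxy leave with it and chloro brings neither, so a hydroxy group is not needed at this position for the cytotoxicity read here. Nothing shown gives a reason for this result.

Going by these compounds, two groups say little about how wide the tolerance at this position really is, and whether an amine, a carboxylic acid or a longer chain such as butoxy would leave the number level remains open. Also open, on these data alone, is how the series would read with plain hydrogen at this position, and whether the same freedom holds elsewhere on the aromatic ring.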